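Replacing fluoro with methyl in compound 2

This account rests on a few compounds, and the source may have more. Where it says the series, first, only, none or still open, it means among the compounds named here.

In a functional assay on MOLT-4 cells (Homo sapiens) for inhibition (on this read-out lower numbers stand for stronger inhibition and higher numbers for weaker inhibition), compound 1 (`O=C1/C(=C/c2cccc(Br)c2)Cc2ccccc21`) gives 173000 nM, compound 2 (`O=C1/C(=C/c2ccc(F)cc2)CCc2ccccc21`) gives 41200 nM and compound 3 (`Cc1cccc(/C=C2\CCc3ccccc3C2=O)c1`) gives 35800 nM. Compound 2 thus sits within the scatter of compound 3, while compound 1 stands apart from compound 2 at a higher number, beyond the scatter. Compound 4 (`Cc1ccc(/C=C2\CCc3ccccc3C2=O)cc1`) has methyl in place of fluoro on an aromatic carbon, para to a large group: methyl in place of fluoro on an aromatic carbon. Within the data shown here, no measured pair shows this exchange, but compound 3, which also carries methyl, reads 35800 nM. The expected change, a 1.1-fold lower number from compound 2 to compound 4 (0.04 log units; within the scatter), is no step beyond the scatter. Compound 4 is estimated at 38000 nM, with an expected range of 18000 nM to 80000 nM.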

Compound 4, half-maximal inhibitory concentration: > 500000 nM
Compound 4 was reported as a limit (the forecaster's own chance of this, stated with the estimate: 5%); middle value at least 13-fold (1.11 log units) away from the limit.
By their numbers in this assay, from the lowest: compounds 3 and 2 (each within the scatter of the next); then compound 1. At a limit, above all of these: compound 4.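

In this assay, methyl in place of fluoro on this aromatic carbon, para to a large group, is far from a neutral exchange: the step is an at least 12-fold higher number from compound 2 to compound 4 (1.08 log units; beyond the scatter). Compound 4 gives > 500000 nM, which is a limit and not a number, so the step has no upper end: the limit of > 500000 nM in this assay, at which 1 of the 4 values shown sits. The presence of methyl alone does not set the reading, as compound 3, which also carries methyl, gives 35800 nM. Going by these compounds, whether chloro or an amine on this same aromatic carbon would read closer to compound 2 or to compound 4 stays open.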